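The source may hold more compounds than are shown below. What is called first, only, known or untested is meant among the compounds shown, and "the series" means these compounds.

Of the compounds shown here, two have been measured so far in an ADME assay on microsomes from liver (Homo sapiens) for metabolic stability, read by LC-MS, using NADPH, with a stated time of 30 min, tested at 0.1 uM, in the presence of a further agent that is not named here; a higher number here means that more of the compound is left, a lower number that less of the compound is left. Compound 1 (`Nc1ncc(-c2ccc(C(=O)N3CCC(O)C3)cc2)nc1-c1ccc(C(F)(F)F)cc1`) gives > 90%, which is a limit of the assay and not an exact number. Compound 2 (`Nc1ccc(-c2nc(-c3ccc(S(=O)(=O)C4CC4)cc3)cnc2N)cn1`) gives > 90%, which is also a limit. Going by the values given here, compound 2 therefore stands at the top of what this assay can report, alongside the only other measured compound. Compound 3 (`N#Cc1ccc(-c2cnc(N)c(-c3ccc(N)nc3)n2)cc1`) keeps the core of compound 2 but carries cyano in place of cyclopropylsulfonyl on an aromatic carbon, para to a large group: cyano in place of cyclopropylsulfonyl on an aromatic carbon. Among the compounds with values here, no measured pair of compounds tests this swap, so the expectation rests only on (the limit of > 90% in this assay, at which 2 of the 2 values shown sit). The expected step of a number no higher from compound 2 to compound 3 (the limit leaves the size open) is none beyond the usual scatter, with no clear direction. Compound 3 is estimated at 90%, with an expected range from 72% to 100%.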

Compound 3, percent of the compound remaining in the Homo sapiens assay: > 90%
Compound 3: a limit, no number (the forecaster's own chance of this, stated with the estimate: 50%); the middle value sits exactly at the limit.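

No step from compound 2 to compound 3 can be read in the Homo sapiens assay since both results are limits and not exact numbers: the limit of > 90% in the Homo sapiens assay, at which 3 of the 3 values shown sit.

In the Homo sapiens assay compound 3 gives > 90% as a limit of the assay and not a number.

The compounds shown leave open how much of each is truly left, and whether cyano in place of cyclopropylsulfonyl changes that amount at all.

In a physicochemical assay for solubility, read by HPLC, using the shake flask method, with a stated time of 2 h, at pH 2 (a lower number here means a less soluble compound, a higher number a more soluble compound), compound 2 gives 212000 nM and compound 3 gives 208000 nM and these two values lie within the scatter of each other.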